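This account rests on a few compounds, and the source may have more. Where it says the series, first, only, none or still open, it means among the compounds named here.

Of the compounds shown here, two sharing one core have been measured in a functional assay on MGC-803 cells (Homo sapiens) for inhibition, read by MTT assay, with a stated time of 72 h; on this read-out lower numbers stand for stronger inhibition and higher numbers for weaker inhibition. Compound 1, `O=C(CSc1nc(Nc2ccccc2)c2ccccc2n1)Nc1ccccc1Br`, gives 18600 nM in this assay. Compound 2, `CCc1ccc(NC(=O)CSc2nc(Nc3ccccc3)c3ccccc3n2)cc1`, reaches only the limit of this assay, reported as > 50000 nM. The step of an at least 2.6-fold higher number from compound 1 to compound 2 (0.42 log units; beyond the scatter) therefore rests on a limit rather than on a number, as the line the limit of > 50000 nM in this assay, at which 1 of the 2 values shown sits, records. Compound 3, `O=C(CSc1nc(Nc2ccccc2)c2ccccc2n1)Nc1ccc(Cl)c(Cl)c1`, has not yet been measured; it differs from compound 2 by 3,4-dichlorophenyl in place of 4-ethylphenyl on an amide-type nitrogen. Going by the values given here, the one measured step that bears on this change runs in the opposite sense: exchanging a halogenated aryl on the amide-type nitrogen for 4-ethylphenyl raised the number, at least modestly, in the step already described. Compound 3 brings a halogenated aryl back to that position, though not the same one as in compound 1, so a move back towards the range of compound 1 is expected, downward in direction and uncertain in size. The number for compound 3 in this assay is estimated at 30000 nM, between 10000 nM and 60000 nM. This corresponds to an expected step of an at least 1.6-fold lower number from compound 2 to compound 3 (0.22 log units; that floor lies within the scatter).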

Compound 3, half-maximal inhibitory concentration: 37900 nM
The estimate for compound 3 lay 1.3-fold (0.10 log units) below the measured number; the measured number falls inside the stated range.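

In this assay, the two halogenated aryl groups on the amide-type nitrogen do not read alike, with a 2.0-fold higher number from compound 1 to compound 3 (0.31 log units; beyond the scatter), so among these compounds a halogenated aryl at this position does not by itself match compound 1. Set against 4-ethylphenyl, 3,4-dichlorophenyl gives an at least 1.3-fold lower number from compound 2 to compound 3 (0.12 log units; that floor lies within the scatter), so this step does not establish a real gain over compound 2, and the earlier drop from 2-bromophenyl to 4-ethylphenyl is not shown to be reversed by any halogenated aryl. The value of compound 2 is a limit, and the step to compound 3 rests on it: the limit of > 50000 nM in this assay, at which 1 of the 3 values shown sits.

On these data alone, whether the gap between compound 1 and compound 3 follows the kind of halogen or where it sits on the ring stays open, as 2-bromophenyl and 3,4-dichlorophenyl differ in both. Also open, as far as these compounds go, is how a plain phenyl, or a phenyl carrying an amine or a carboxylic acid, would read on this nitrogen, and whether any change elsewhere on the shared core would matter more than this one.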